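Pyridyloxy variation on the shared core: permeability notes

The source may report more compounds than this note shows. Statements on the series, on what has been measured and on what is new or still open speak of the compounds shown alone.

The series keeps one core and changes only the pyridine on the aryl ether oxygen. Compound 1 `Cc1ccnc(Oc2ccc3nc(COc4cccc(C(=O)O)c4)n(C)c3c2)c1` gives 3.5 10^-6 cm/s in an ADME assay for permeability, using PAMPA, with a stated time of 4 h; a lower number here means that the compound crosses the layer more slowly, a higher number that the compound crosses the layer faster. Compound 2 `Cn1c(COc2cccc(C(=O)O)c2)nc2ccc(Oc3ccc(F)cn3)cc21` gives 4.7 10^-6 cm/s in this assay, and compound 3 `Cc1cnc(Oc2ccc3nc(COc4cccc(C(=O)O)c4)n(C)c3c2)c(F)c1` gives 5.8 10^-6 cm/s. All three values lie within the scatter of one another: a 1.3-fold higher number from compound 1 to compound 2 (0.13 log units; within the scatter), a 1.7-fold higher number from compound 1 to compound 3 (0.22 log units; within the scatter) and a 1.2-fold higher number from compound 2 to compound 3 (0.09 log units; within the scatter). Compound 3 sits nearest to compound 2 and furthest from compound 1, with neither distance beyond the scatter.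

Compound 4 `Cc1cc(F)cnc1Oc1ccc2nc(COc3cccc(C(=O)O)c3)n(C)c2c1` has not yet been measured in this assay. It differs from compound 3 only in the pyridine: 5-fluoro-3-methylpyridin-2-yl in place of 3-fluoro-5-methylpyridin-2-yl on an oxygen on an aromatic ring, so the same atoms are present, joined differently. Going by the values given here, the steps that bear on this are a 1.7-fold higher number from compound 1 to compound 3 (0.22 log units; within the scatter) and a 1.2-fold higher number from compound 2 to compound 3 (0.09 log units; within the scatter), both rearrangements of the pyridine substituents that stayed within the scatter. No step beyond the scatter is therefore expected here; the step of a 1.1-fold lower number from compound 3 to compound 4 (0.04 log units; within the scatter) is estimated to be small in either direction. Compound 4 is expected to give about 5.3 10^-6 cm/s in this assay, within a range of 2.8 10^-6 cm/s to 9.5 10^-6 cm/s.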

Compound 4, apparent permeability in the ADME assay: 8.3 10^-6 cm/s
Estimate against measurement, compound 4: 1.6-fold (0.19 log units) below, and the stated range covers the measured number.
By their numbers in the ADME assay, from the lowest: compounds 1, 2, 3 and 4 (each within the scatter of the next, the first and the last beyond it).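

In the ADME assay compound 2 gives 4.7 10^-6 cm/s and compound 3 gives 5.8 10^-6 cm/s and compound 4 gives 8.3 10^-6 cm/s while the exchange of 3-fluoro-5-methylpyridin-2-yl for 5-fluoro-3-methylpyridin-2-yl, the same atoms joined differently, reads as a 1.4-fold higher number from compound 3 to compound 4 (0.16 log units; within the scatter) and methyl in place of hydrogen on an aromatic carbon reads as a 1.8-fold higher number from compound 2 to compound 4 (0.25 log units; within the scatter) so neither change alone separates the compounds. Going by these compounds alone, the pyridine on this oxygen does separate a pair in the ADME assay with a 2.4-fold higher number from compound 1 to compound 4 (0.38 log units; beyond the scatter) which is the first step beyond the scatter, though only a modest one. In a physicochemical assay for solubility, read by HPLC, measured as thermodynamic solubility, with a stated time of 4 h, at pH 6.8 (on this read-out lower numbers stand for lower solubility and higher numbers for higher solubility), compound 3 gives 9.2 ug/mL and compound 4 gives 14 ug/mL and the same exchange reads as a 1.5-fold higher number from compound 3 to compound 4 (0.18 log units; within the scatter) so this pair stays unseparated on both read-outs.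

Nothing available here explains any of these steps.

Still open, as far as these compounds go, is whether a methoxy group or a nitrile on the pyridine, or a phenyl ring in place of the pyridine, would extend the step beyond the scatter.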